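This account rests on a few compounds, and the source may have more. Where it says the series, first, only, none or still open, it means among the compounds named here.

Compound 1 `COC(=O)C(=O)Nc1cccc(C(=O)/C=C/c2ccc(O)c(OC)c2)c1` and compound 2 `CCOC(=O)C(=O)Nc1cccc(C(=O)/C=C/c2ccc(O)c(OC)c2)c1` share one core. In a functional assay on HUVEC cells (Homo sapiens) for inhibition, tested at 10 ug/mL (a higher number here means a stronger effect of the compound at the concentration tested, a lower number a weaker effect), compound 1 gives 43%, while compound 2 gives 66%; the step of a number 23 percentage points higher from compound 1 to compound 2 (beyond the scatter) is the only one measured so far, and compound 2 therefore stands highest of the two numbers seen.

Compound 3 `COc1cc(/C=C/C(=O)c2cccc(NC(C)=O)c2)ccc1O` carries the change (methyl in place of ethoxycarbonyl on a carbonyl carbon). Among the compounds with values here, only the step from compound 1 to compound 2 bears on it, and only loosely, since there the ester was kept; its size, a number 23 percentage points higher from compound 1 to compound 2 (beyond the scatter), suggests that trimming this group matters. A downward step is expected, a number 16 percentage points lower from compound 2 to compound 3 (beyond the scatter). Compound 3 is thus estimated at 50%, between 25% and 75%.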

Compound 3, a percentage reported as inhibition, at one concentration (the size of the read-out at that concentration, not a potency): 32%
Beside the measured number, compound 3's estimate is 18 percentage points above it; the range from low to high includes it.
By their numbers in this assay, from the lowest: compound 3; then compound 1; then compound 2.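

In this assay, methyl in place of ethoxycarbonyl on the carbonyl carbon gives a number 34 percentage points lower from compound 2 to compound 3 (beyond the scatter), and methyl in place of methoxycarbonyl gives a number 11 percentage points lower from compound 1 to compound 3 (beyond the scatter). The acetamido end of compound 3 thus reads below both ester ends, so the number at this position depends on more than the alkyl part of the ester, the only part varied before. No available evidence accounts for these drops. Open, going by these compounds, is how a carboxylic acid, an amine or a longer ester chain at this position would read.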